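This account rests on a few compounds, and the source may have more. Where it says the series, first, only, none or still open, it means among the compounds named here.

Measured so far, in a functional assay on MCF7 cells (Homo sapiens) for inhibition, read by MTT assay, with a stated time of 48 h; a higher number here means a weaker inhibitor, a lower number a stronger inhibitor:

compound 1, `Clc1cccc(CSc2nnc(-c3ccncc3)n2-c2ccccc2)c1`, gives 10500 nM
compound 2, `Brc1cccc(CSc2nnc(-c3ccncc3)n2-c2ccccc2)c1`, gives 10000 nM
compound 3, `O=C(CSc1nnc(-c2ccncc2)n1-c1ccccc1)N/N=C/c1ccccc1`, gives 23600 nM

All three compounds share the same core and differ only in the group carried on the sulfur. Among the three numbers, compound 3 has the highest, with the other two standing beyond the scatter below it, so in this assay compound 3 is the weakest inhibitor of the set.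

Compound 4, `O=C(CSc1nnc(-c2ccncc2)n1-c1ccccc1)N/N=C/c1ccc(Cl)cc1`, is compound 3 with one change: chloro in place of hydrogen on an aromatic carbon. Going by the values given here, the only measured step among the three compounds is a 1.1-fold lower number from compound 1 to compound 2 (0.02 log units; within the scatter), which exchanges one halogen for another rather than putting a halogen where a hydrogen stood, so it bears on the present step only loosely. It does show that changing a halogen on that outer ring left the number almost where it was. Among the compounds with values here, with no closer precedent, the step of a 1.2-fold lower number from compound 3 to compound 4 (0.07 log units; within the scatter) is expected to stay within the scatter, in no clear direction. Compound 4 is therefore estimated at 20000 nM, with a range from 8000 nM to 50000 nM.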

Compound 4, half-maximal inhibitory concentration: 9930 nM
Compound 4: the middle estimate sits 2.0-fold (0.30 log units) above what was measured; low and high end bracket the measured number.
By their numbers in this assay, from the lowest: compounds 4, 2 and 1 (each within the scatter of the next); then compound 3.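

In this assay, the change from phenyl to 4-chlorophenyl gives a 2.4-fold lower number from compound 3 to compound 4 (0.38 log units; beyond the scatter) and so makes compound 4 the stronger inhibitor of this pair. This is the first listed step to pass beyond the scatter, although it remains modest. The earlier step exchanged one halogen for another and left the number almost unchanged, whereas this one shows that chloro in place of hydrogen on an aromatic carbon, para to a large group, can shift the number on this side chain; no measurement available here accounts for the shift.

The compounds shown leave open whether this gain is particular to chloro or would also appear with fluoro, methoxy or an amine at the same place. They also leave open whether chloro would give a similar step elsewhere on this ring.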